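This account rests on a few compounds, and the source may have more. Where it says the series, first, only, none or still open, it means among the compounds named here.

Within the data shown here, the three compounds measured so far share one core and differ only in the aromatic group attached to the amine. Compound 1 `Oc1nc2nonc2nc1Nc1ccccc1F` carries a fluoro on that ring; in an assay on mitochondria from L6 cells (Rattus norvegicus) for activation, with a stated time of 90 min (a higher number here means that more compound is needed for the effect, a lower number that less compound is needed), compound 1 gives 12500 nM. Compound 2 `Oc1nc2nonc2nc1Nc1ccc(OCc2ccccc2)cc1` carries a benzyloxy group instead, and in this assay compound 2 gives 2400 nM. Compound 3 `Oc1nc2nonc2nc1Nc1ccc2ccccc2c1` carries a different aromatic group altogether, and in this assay compound 3 gives 4000 nM.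

Among these three numbers, compound 2 has the lowest. Its gap to compound 3 lies within the usual scatter, so no order between those two can be claimed; its gap to compound 1 lies beyond the scatter.

Compound 4 `Oc1nc2nonc2nc1Nc1ccc(F)cc1` has not yet been measured in this assay. Relative to compound 2, the change is fluoro in place of benzyloxy on an aromatic carbon.

Among the measured compounds shown here, because compound 1, the only other member bearing a fluoro, gives 12500 nM, compound 4 is expected to need more compound than compound 2 rather than less. The expected step of a 4.2-fold higher number from compound 2 to compound 4 (0.62 log units; beyond the scatter) is thought to lie beyond the scatter. Compound 4 is therefore estimated at 10000 nM, with a likely range from 3000 nM to 30000 nM.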

Compound 4, half-maximal effective concentration: 38600 nM
Compound 4: the middle estimate sits 3.9-fold (0.59 log units) below what was measured; the measured number lies above the stated range.
By their numbers in this assay, from the lowest: compounds 2 and 3 (each within the scatter of the next); then compound 1; then compound 4.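

In this assay, putting fluoro in place of benzyloxy on this aromatic carbon gives a 16-fold higher number from compound 2 to compound 4 (1.21 log units; beyond the scatter), a large step and the first one available between two compounds that differ in a single place. The change removes a whole group, with its oxygen and its six-membered aromatic ring of carbon only, and leaves a lone fluorine, so this one pair shows that the number at this position can move widely, and that fluoro here sits far from benzyloxy; compound 4 at 38600 nM also stands apart from the other fluoro compound, compound 1, at 12500 nM, so the presence of a fluoro does not by itself fix the number. Nothing measured here explains why the step is so large.

The compounds shown leave open which part of benzyloxy carries the difference, since a methoxy or a phenoxy group would separate the oxygen, the linking carbon and the outer ring. They also leave open whether an unrelated group at this position, such as an amine, a carboxylic acid or a longer alkoxy chain, would give a number close to that of compound 2 or that of compound 4.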